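A few compounds are considered here, and "the series" means these few. Any claim that something is new, unique, unknown or untested is made for them only; others in the source may bear on it.

Measured compounds:
- Compound 1 `O=C(Nc1cccc(-c2oc3cc(-c4ccc(F)cc4)ccc3c(=O)c2O)c1)c1ccc(F)cc1F`: 20500 nM
- Compound 2 `O=C(Nc1cccc(-c2oc3cc(-c4ccc(F)cc4)ccc3c(=O)c2O)c1)c1ccc(Cl)nc1`: 3580 nM

Two compounds of the series have been run in a functional assay on A549 cells (Homo sapiens) for antiproliferative activity, read by CCK-8 assay, with a stated time of 72 h; a higher number here means a weaker inhibitor, a lower number a stronger inhibitor. Among the measured compounds shown here, compound 1 gives 20500 nM and compound 2 gives 3580 nM; the only step so far is a 5.7-fold lower number from compound 1 to compound 2 (0.76 log units; beyond the scatter), so compound 2 holds the lowest of the two numbers, with compound 1 the nearest neighbour.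

Compound 3 `O=C(Nc1cccc(-c2oc3cc(-c4ccc(F)cc4)ccc3c(=O)c2O)c1)c1ccc(-c2ccccc2)cc1` is not yet measured. It keeps the shared core of compound 2 and changes the group on the carbonyl carbon: 4-phenylphenyl in place of 6-chloropyridin-3-yl on a carbonyl carbon. For the measured compounds named here, the one measured step bears on it only loosely, as it shows that swapping the aryl group on that carbonyl carbon between compound 1 and compound 2 moved the number well beyond the scatter. Going by the values given here, no step to a 4-phenylphenyl amide exists. The expectation for compound 3 is therefore uncertain: the step of a 2.2-fold higher number from compound 2 to compound 3 (0.35 log units; beyond the scatter) is estimated to go upward, possibly beyond the scatter, with a wide range. Compound 3 is estimated at 8000 nM, within 1500 nM to 40000 nM.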

Compound 3, half-maximal inhibitory concentration: > 100000 nM
Compound 3 ended at the assay's limit; the forecaster's own chance of this, stated with the estimate: 10%; at least 12-fold (1.09 log units) between middle value and limit.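

In this assay compound 3 gives a limit of the assay and not a number: the limit of > 100000 nM in this assay, at which 1 of the 3 values shown sits. On the carbonyl carbon, 4-phenylphenyl in place of 6-chloropyridin-3-yl gives an at least 27-fold higher number from compound 2 to compound 3 (1.44 log units; beyond the scatter), and 4-phenylphenyl in place of 2,4-difluorophenyl gives an at least 4.8-fold higher number from compound 1 to compound 3 (0.68 log units; beyond the scatter), so the two single-ring groups, which alone had shown a 5.7-fold lower number from compound 1 to compound 2 (0.76 log units; beyond the scatter), both stay on the lower side of the group with two six-membered aromatic rings of carbon only. Among the compounds shown here, this position therefore does more than shift the number among aryl amides: among the three compounds, the largest group, with 12 heavy atoms, is the one that reaches the limit, and no compound goes against that order.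

On these data alone, the true size of both new steps stays unknown, and these compounds cannot separate the effect of the second ring from that of the loss of the ring nitrogen and the halogens. An unsubstituted phenyl, a benzyl group, or a phenyl ring carrying an amine or a carboxylic acid on that carbonyl carbon would help to tell these apart.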